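Changing the Ring-Nitrogen Group of Compound 2

This account rests on a few compounds, and the source may have more. Where it says the series, first, only, none or still open, it means among the compounds named here.

Three compounds share one core and differ only in where a hydroxyl sits on the ring that carries the carbonyl. In an assay on isolated protein for binding affinity to 5-hydroxytryptamine receptor 7 (Rattus norvegicus) (on this read-out higher numbers stand for weaker inhibition and lower numbers for stronger inhibition), compound 1 `COc1ccccc1N1CCN(CCCCC(=O)c2cccc(O)c2)CC1` gives 15 nM, compound 2 `COc1ccccc1N1CCN(CCCCC(=O)c2ccccc2O)CC1` gives 16.4 nM, and compound 3 `COc1ccccc1N1CCN(CCCCC(=O)c2ccc(O)cc2)CC1` gives 59.1 nM. Compound 2 thus stands second highest of the three numbers: the step of a 1.1-fold higher number from compound 1 to compound 2 (0.04 log units; within the scatter) is within the scatter, while the step of a 3.6-fold higher number from compound 2 to compound 3 (0.56 log units; beyond the scatter) and the step of a 3.9-fold higher number from compound 1 to compound 3 (0.60 log units; beyond the scatter) are beyond it.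

Compound 4 `O=C(CCCCN1CCN(c2noc3ccccc23)CC1)c1ccccc1O` differs from compound 2 at another place: a group of 9 heavy atoms (7 carbon, 1 nitrogen, 1 oxygen; one five-membered aromatic ring with 2 hetero atoms, one six-membered aromatic ring of carbon only) in place of a group of 8 heavy atoms (7 carbon, 1 oxygen; one six-membered aromatic ring of carbon only), on an amine nitrogen in a ring. None of the three measured steps touches this position; all three move only the hydroxyl on the ring at the carbonyl, so they give no guide to the size or direction of this change. With nothing bearing on it, the expectation for compound 4 in this assay is a number close to that of compound 2, with a wide range: an estimated 20 nM, between 4 nM and 100 nM. The expected step of a 1.2-fold higher number from compound 2 to compound 4 (0.09 log units; within the scatter) is accordingly no change beyond the scatter, though the range allows one either way.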

Compound 4, inhibition constant: 52 nM
Compound 4: the middle estimate sits 2.6-fold (0.41 log units) below what was measured, and the stated range covers the measured number.
By their numbers in this assay, from the lowest: compounds 1 and 2 (each within the scatter of the next); then compounds 4 and 3 (each within the scatter of the next).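

The result shows that the group on the ring nitrogen matters for this read-out, which the hydroxyl moves could not reveal. In this assay, replacing the 2-methoxyphenyl with the group carrying a five-membered and a six-membered aromatic ring gives a 3.2-fold higher number from compound 2 to compound 4 (0.50 log units; beyond the scatter), a modest weakening. The two groups differ by only one heavy atom, so a swap of nearly equal atom count can still shift the number, though no evidence here explains why.

With one replacement shown, it remains open how a plain phenyl or a 2-ethoxyphenyl at this place would compare with the 2-methoxyphenyl. Going by these compounds, it is also open whether the same swap would shift the number similarly with the hydroxyl placed as in compound 1 or compound 3.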